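A few compounds are considered here, and "the series" means these few. Any claim that something is new, unique, unknown or untested is made for them only; others in the source may bear on it.

Compound 1, `COc1ccc([C@H]2CC(=O)N(c3ccc(C)c(N)c3)C2)cc1OC1CCCC1`, is the starting point of this comparison. In a functional assay on HEK293 cells (Homo sapiens) for cytotoxicity (a lower number here means that less compound is tolerated, a higher number that more compound is tolerated), compound 1 gives > 10000 nM, which is a limit of the assay and not a number. Compound 2, `COc1ccc([C@H]2CC(=O)N(c3ccccc3C(F)(F)F)C2)cc1OC1CCCC1`, also reaches only a limit: in this assay compound 2 gives > 10000 nM. For the measured compounds named here, compound 3, `COc1ccc([C@H]2CC(=O)N(c3ccc([S+](C)[O-])cc3)C2)cc1OC1CCCC1`, is the one neighbour with a real number, as compound 3 gives 7510 nM. The three measured steps are therefore thin: a step that the two limits leave unreadable from compound 1 to compound 2 cannot be read, while an at least 1.3-fold lower number from compound 1 to compound 3 (0.12 log units; that floor lies within the scatter) and an at least 1.3-fold lower number from compound 2 to compound 3 (0.12 log units; that floor lies within the scatter) are known only as floors, and both floors lie within the scatter. The picture rests on (the limit of > 10000 nM in this assay, at which 2 of the 3 values shown sit), so nothing in these data says that any change on the amide-type nitrogen moves tolerance beyond the scatter.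

Compound 4, `COc1ccc([C@H]2CC(=O)N(c3ccc(S(C)(=O)=O)cc3)C2)cc1OC1CCCC1`, differs from compound 1 in one place: 4-(methylsulfonyl)phenyl in place of 3-amino-4-methylphenyl on an amide-type nitrogen in a ring. Going by the values given here, the step that bears most on it is the one to compound 3, whose value sits close to the limit the other two reach. Compound 4 is expected to give about 8000 nM, within 3500 nM to 15000 nM, since compound 3 gives 7510 nM. That amounts to an expected at least 1.2-fold lower number from compound 1 to compound 4 (0.09 log units; that floor lies within the scatter), a step that may well remain unreadable against the limit.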

Compound 4, half-maximal cytotoxic concentration: > 10000 nM
Compound 4 ended at the assay's limit; the forecaster's own chance of this, stated with the estimate: 45%; middle value at least 1.2-fold (0.09 log units) from the limit.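

In this assay compound 4 sits at a limit of the assay, as compound 1 and compound 2 do, and the steps among these three cannot be read. For the compounds shown here, the one new step that can be read is an at least 1.3-fold higher number from compound 3 to compound 4 (0.12 log units; that floor lies within the scatter), so the move to the methylsulfonyl group on the aromatic carbon is known only as a floor and does not show a difference from compound 3 beyond the scatter. What compound 4 adds is a third, different group on the amide-type nitrogen in a ring that reaches the limit, which leaves the comparison at this position tied even more closely to that ceiling: the limit of > 10000 nM in this assay, at which 3 of the 4 values shown sit.

Going by these compounds alone, compound 3 gives 7510 nM and remains the only compound here with a real number. On these data alone, how far the other three lie past the limit, and whether any change at this position moves tolerance beyond the scatter, stays open. Also open, as far as these compounds go, is what a carboxylic acid or a nitrile in place of the methylsulfonyl group would give in this assay.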